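A few compounds are considered here, and "the series" means these few. Any claim that something is new, unique, unknown or untested is made for them only; others in the source may bear on it.

Measured compounds:
- Compound 1 `COc1ccc(CNc2nc([Se]C)nc3ccccc23)cc1`: > 100000 nM in an ADME assay on BEAS-2B cells (Homo sapiens) for cytotoxicity, read by MTT assay, with a stated time of 72 h; a lower number here means a stronger inhibitor of growth, a higher number a weaker inhibitor of growth
- Compound 2 `C[Se]c1nc(N)c2ccccc2n1`: 54600 nM in this assay
- Compound 3 `CCCCC[Se]c1nc([Se]CCCCC)c2ccccc2n1`: > 100000 nM in this assay

The value for compound 1 is a limit of the assay, not a number. The value for compound 3 is likewise a limit of the assay. Among the three measured compounds only compound 2 gives a number, and compound 3 sits at the limit of > 100000 nM in this assay, at which 2 of the 3 values shown sit.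

Compound 4 `CCCCC[Se]c1nc(NCc2ccccc2)c2ccccc2n1` is not yet measured. It differs from compound 3 by one change: a group of 8 heavy atoms (7 carbon, 1 nitrogen; one six-membered aromatic ring of carbon only) in place of a group of 6 heavy atoms (5 carbon, 1 selenium; no ring), on an aromatic carbon. Put in words, a group of 8 heavy atoms (7 carbon, 1 nitrogen; one six-membered aromatic ring of carbon only) takes the place of a group of 6 heavy atoms (5 carbon, 1 selenium; no ring), on an aromatic carbon.

Within the data shown here, no pair of measured compounds differs in just one place, so no measured step can guide the size of the change. Among the measured compounds shown here, compound 1, which also carries a benzylamino-type group on the shared core, sits at the same limit as compound 3, and compound 2, with a plain amino group instead, is the only one with a number. On that basis the step from compound 3 to compound 4 is expected to stay within the scatter and most likely to end at the limit again, as a number no higher from compound 3 to compound 4 (the limit leaves the size open). Compound 4 is therefore estimated at 100000 nM, with a range from 40000 nM to 250000 nM.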

Compound 4, concentration for total growth inhibition: > 100000 nM
Compound 4: a limit, no number; the forecaster's own chance of this, stated with the estimate: 65%; the middle value sits exactly at the limit.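

In this assay compound 3 and compound 4 both give a limit of the assay rather than a number, so no step can be read between them: the limit of > 100000 nM in this assay, at which 3 of the 4 values shown sit. The compounds shown leave open whether benzylamino, in place of the group of 6 heavy atoms, changes growth inhibition at all.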